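From phenyl to 1H-pyrrol-2-yl: compound 3 to compound 4

A few compounds are considered here, and "the series" means these few. Any claim that something is new, unique, unknown or untested is made for them only; others in the source may bear on it.

In a functional assay on Caco-2 cells (Homo sapiens) for cytotoxicity, read by MTT assay, with stated times of 6 h and 48 h (a higher number here means a weaker inhibitor, a lower number a stronger inhibitor), compound 1 (`Cn1c(/C=C/C(=O)c2ccccc2O)cc(Br)c1Br`) gives 3160 nM as its reading. Compound 3 (`Cn1c(-c2cc(-c3ccccc3)no2)cc(Br)c1Br`) gives 16600 nM as its reading, which makes it the higher of the two actual numbers, with a gap to compound 1 that lies beyond the scatter. Within the data shown here, compound 2 (`Cn1c(/C=C/C(=O)c2ccc[nH]2)cc(Br)c1Br`), the only measured compound bearing 1H-pyrrol-2-yl, gives >= 100000 nM as its entry, and this is a limit of the assay, not a number.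

Compound 4 (`Cn1c(-c2cc(-c3ccc[nH]3)no2)cc(Br)c1Br`) differs from compound 3 in one place, with 1H-pyrrol-2-yl in place of phenyl on an aromatic carbon. Among the measured compounds shown here, no measured pair shows this change directly, so the expectation rests only on that single limit. A moderate rise in the number is expected in this assay for this change, and the estimated step (a 2.4-fold higher number from compound 3 to compound 4 (0.38 log units; beyond the scatter)) means a weaker inhibitor. For compound 4 the estimated value is 40000 nM as a central figure, with an expected range from 10000 nM to 100000 nM in this measurement.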

Compound 4, half-maximal inhibitory concentration: >= 100000 nM
Compound 4 ended at the assay's limit (the forecaster's own chance of this, stated with the estimate: 25%); middle value at least 2.5-fold (0.39 log units) away from the limit.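

In this assay, 1H-pyrrol-2-yl in place of phenyl on this aromatic carbon, next to the ring nitrogen, gives an at least 6.0-fold higher number from compound 3 to compound 4 (0.77 log units; beyond the scatter), the only direct measure of this change among the compounds shown. Compound 4 gives >= 100000 nM, which is a limit of the assay and not a number. The step is thus a lower bound on the size of the change, and compound 2 and compound 4, the two compounds bearing 1H-pyrrol-2-yl, both end at that limit: the limit of >= 100000 nM in this assay, at which 2 of the 4 values shown sit.

The compounds shown leave open how far past the limit compound 4 lies, and whether a methyl group on the pyrrole nitrogen would change the reading. They also leave open whether an amine or a carboxylic acid at this position would give a lower or a higher number than compound 3.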